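Quinazoline series: pyrrolidinyl to methyl on the side chain

The compounds below may be only part of what the source reports. "The series", "measured", "known", "first", "only" and "open" are said of these compounds alone.

Measured compounds
- compound 1, `c1coc(CNc2nc(NCCCN3CCCC3)nc3ccccc23)c1`: 16100 nM
- compound 2, `Fc1ccc2nc(NCCN3CCN(c4cccc(Cl)c4Cl)CC3)nc(NCc3ccco3)c2c1`: 1010 nM

Of the compounds shown here, two of the shared core have been measured in a functional assay on HCT-116 cells (Homo sapiens) for cytotoxicity, read by MTT assay, with a stated time of 2 days; on this read-out lower numbers stand for stronger inhibition and higher numbers for weaker inhibition. Compound 1 gives 16100 nM in this assay, the highest of the two numbers; the nearest neighbour is compound 2, whose value of 1010 nM sits far lower, well beyond the scatter. For the measured compounds named here, no single-point step between measured compounds is available, so the two values can only be set side by side.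

The unmeasured compound 3, `CCCCNc1nc(NCc2ccco2)c2ccccc2n1`, departs from compound 1 by one change: methyl in place of pyrrolidin-1-yl on a saturated chain carbon, three bonds along the chain from a nitrogen on an aromatic ring. Nothing measured in this assay isolates the effect of exchanging pyrrolidin-1-yl for methyl on this chain, so the expectation rests on the position of compound 1 alone. The step from compound 1 is expected to be modest and, if anything, toward a higher number: a 1.6-fold higher number from compound 1 to compound 3 (0.19 log units; within the scatter). Compound 3 is therefore estimated at 25000 nM in this assay, with a range from 8000 nM to 70000 nM.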

Compound 3, half-maximal inhibitory concentration: 5470 nM
The estimate for compound 3 lay 4.6-fold (0.66 log units) above the measured number; the whole stated range lies above it.
By their numbers in this assay, from the lowest: compound 2; then compound 3; then compound 1.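

In this assay, for the compounds shown here, the exchange of pyrrolidin-1-yl for methyl on a saturated chain carbon, three bonds along the chain from a nitrogen on an aromatic ring, gives a 2.9-fold lower number from compound 1 to compound 3 (0.47 log units; beyond the scatter) and is the first single-change step available. The direction shows that the ring and its nitrogen are not needed at the chain end for activity in this read-out: with the shared core held constant, the difference read as 3-(pyrrolidin-1-yl)propyl to butyl gives a lower number, although it removes a ring and a hydrogen-bond acceptor. No available evidence bears on why the number moves this way.

One step cannot separate the loss of the ring from the loss of the amine nitrogen, so an open-chain dimethylamino group or a hydroxyl group at the end of the same propyl chain remains the needed comparison. Going by these compounds, it also remains open whether the lower number extends to other plain alkyl chains, such as a propyl or hexyl chain in place of butyl, or holds on a core carrying other substituents.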